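Phenyl to 4-bromo-2-fluorophenyl on the shared core

The source may report more compounds than this note shows. Statements on the series, on what has been measured and on what is new or still open speak of the compounds shown alone.

Measured compounds:
compound 1, `Cn1ccc2c(Oc3ccc(NC(=O)c4cn(-c5ccc(Br)cc5F)c5ccccc5c4=O)cc3F)ccnc21`, 1520 nM
compound 2, `O=C(Nc1ccc(Oc2ccnc3[nH]ccc23)c(F)c1)c1cn(-c2ccccc2)c2ccccc2c1=O`, 420 nM

Among the compounds with values here, in a functional assay on A549 cells (Homo sapiens) for inhibition, read by MTT assay, with a stated time of 72 h (a higher number here means a weaker inhibitor, a lower number a stronger inhibitor), compound 2 gives 420 nM, the lower of the two numbers known so far. In this assay compound 1 gives 1520 nM; the gap between the two lies beyond the usual scatter, but compounds 1 and 2 differ in more than one place, so no single change can be read from that pair.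

Compound 3, `O=C(Nc1ccc(Oc2ccnc3[nH]ccc23)c(F)c1)c1cn(-c2ccc(Br)cc2F)c2ccccc2c1=O`, is not yet measured. It differs from compound 2 in one place: 4-bromo-2-fluorophenyl in place of phenyl on an aromatic nitrogen. As far as these compounds go, the same 4-bromo-2-fluorophenyl group is present in compound 1, which gives the weaker of the two measured numbers, though its core also differs from that of compound 2, so the contribution of the aryl group alone is unknown here.

On that basis, a modest loss relative to compound 2 is expected, roughly a 1.9-fold higher number from compound 2 to compound 3 (0.28 log units; within the scatter), without certainty that it exceeds the scatter. For compound 3 the expected value in this assay is 800 nM, with a range from 300 nM to 2500 nM.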

Compound 3, half-maximal inhibitory concentration: 1150 nM
The estimate for compound 3 lay 1.4-fold (0.16 log units) below the measured number; the measured number falls inside the stated range.
By their numbers in this assay, from the lowest: compound 2; then compounds 3 and 1 (each within the scatter of the next).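

In this assay, the aryl group on the aromatic nitrogen can now be read alone on the shared core. 4-bromo-2-fluorophenyl in place of phenyl gives a 2.7-fold higher number from compound 2 to compound 3 (0.44 log units; beyond the scatter), a modest step that lies beyond the scatter. Compound 1 and compound 3 also now form a pair that differs in one place, and hydrogen in place of methyl on an aromatic nitrogen gives a 1.3-fold lower number from compound 1 to compound 3 (0.12 log units; within the scatter), which stays within the scatter, so of the two single changes only the aryl exchange gives a readable step in this test. No measurement is at hand that would explain the step at the aryl group.

The compounds shown leave open whether the bromine, the fluorine or the pair of them accounts for the step, as a phenyl group carrying only one of these halogens is not among them. As far as these compounds go, it also remains open how this position would respond to a group of another kind on the phenyl ring, such as a methoxy group or an amine.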